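A few compounds are considered here, and "the series" means these few. Any claim that something is new, unique, unknown or untested is made for them only; others in the source may bear on it.

In a functional assay on PC-3 cells (Homo sapiens) for cytotoxicity, read by MTT assay, with a stated time of 72 h (a lower number here means a stronger inhibitor, a higher number a weaker inhibitor), compound 2 `FC(F)(F)c1ccc(CSc2nc(Nc3cccc(Cl)c3)c3ccccc3n2)cc1` gives 13400 nM. Compound 1 `CCCCCCCCNc1nc(SCc2ccc(C(F)(F)F)cc2)nc2ccccc12` gives 10500 nM in this assay. On these two numbers compound 2 has the higher figure, but the gap is within the scatter: the step was a 1.3-fold higher number from compound 1 to compound 2 (0.11 log units; within the scatter). Compound 3 `Fc1ccc(Nc2nc(SCc3ccc(C(F)(F)F)cc3)nc3ccccc23)cc1Cl` differs from compound 2 by fluoro in place of hydrogen on an aromatic carbon. Going by the values given here, no measured step involves a fluoro group, and the one step known was itself within the scatter, so no change beyond the scatter is expected. Compound 3 is therefore estimated at 12000 nM, with a range from 5000 nM to 30000 nM. The expected step is a 1.1-fold lower number from compound 2 to compound 3 (0.05 log units; within the scatter).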

Compound 3, half-maximal inhibitory concentration: 18600 nM
For compound 3 the middle estimate is 1.6-fold (0.19 log units) below the measured one; low and high end bracket the measured number.
By their numbers in this assay, from the lowest: compounds 1, 2 and 3 (each within the scatter of the next).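

In this assay fluoro in place of hydrogen on the aromatic carbon ortho to the chloro group gives a 1.4-fold higher number from compound 2 to compound 3 (0.14 log units; within the scatter) and so shows that this position takes a fluoro group without a change beyond the scatter. Replacing octyl on the nitrogen with 3-chloro-4-fluorophenyl gives a 1.8-fold higher number from compound 1 to compound 3 (0.25 log units; within the scatter) and likewise leaves the two compounds within the scatter of each other. Nothing available explains why these numbers stay so close. Still open, from the compounds shown here alone, is whether an amine, a carboxylic acid or a methoxy group on this carbon would shift the number beyond the scatter.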